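Swapping Benzyl for Tert-Butyl in a Series at the Limit

The compounds below may be only part of what the source reports. "The series", "measured", "known", "first", "only" and "open" are said of these compounds alone.

Three measured compounds share one core and differ only in the group on an aromatic carbon. Compound 1 `[O-]/[N+](=C\c1cn(-c2ccc(F)cc2)nn1)Cc1ccccc1` carries fluoro there; in a functional assay on MDA-MB-231 cells (Homo sapiens) for inhibition, read by MTT assay, with a stated time of 24 h (on this read-out higher numbers stand for weaker inhibition and lower numbers for stronger inhibition), compound 1 gives > 100000 nM, a limit of the assay rather than a number. Compound 2 `COc1ccc(-n2cc(/C=[N+](\[O-])Cc3ccccc3)nn2)cc1` has methoxy in its place, and in this assay compound 2 gives > 100000 nM, again a limit. Compound 3 `[O-]/[N+](=C\c1cn(-c2ccc(C(F)(F)F)cc2)nn1)Cc1ccccc1` carries trifluoromethyl; in this assay compound 3 gives > 100000 nM, also a limit. Because all three sit at the limit of > 100000 nM in this assay, at which 3 of the 3 values shown sit, the steps a step that the two limits leave unreadable from compound 1 to compound 2, a step that the two limits leave unreadable from compound 1 to compound 3 and a step that the two limits leave unreadable from compound 2 to compound 3 cannot be read in size or direction. Compound 4 `COc1ccc(-n2cc(/C=[N+](\[O-])C(C)(C)C)nn2)cc1` differs from compound 2 by tert-butyl in place of benzyl on a double-bonded nitrogen. Going by the values given here, none of the measured steps touches this position, so they give no guide to the change. Compound 2 stands at its limit with nothing pointing away from it. Compound 4 is therefore expected to stay near the limit in this assay, a step of a number no higher from compound 2 to compound 4 (the limit leaves the size open) of no readable size. Compound 4 is estimated at 100000 nM, between 30000 nM and 300000 nM.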

Compound 4, half-maximal inhibitory concentration: 23100 nM
For compound 4 the middle estimate is 4.3-fold (0.64 log units) above the measured one; measured number outside the range, below it.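

In this assay, going by these compounds alone, the group on the double-bonded nitrogen is the first place where a change can be read: tert-butyl in place of benzyl gives an at least 4.3-fold lower number from compound 2 to compound 4 (0.63 log units; beyond the scatter). Compound 4 gives 23100 nM, a measured number, which shows that a change at this position can give this series a readable value. The other compounds remain at a limit of the assay, and their steps on the aromatic carbon cannot be read: the limit of > 100000 nM in this assay, at which 3 of the 4 values shown sit.

The compounds shown leave open whether the step follows the loss of the six-membered aromatic ring, the drop from 7 heavy atoms to 4, or tert-butyl itself, and a cyclohexyl group or a longer carbon chain on the same nitrogen could help to separate these. They also leave open whether fluoro or trifluoromethyl on the aromatic carbon would change the number once tert-butyl is in place.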